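Swapping the Amide Group on Compound 1

This account rests on a few compounds, and the source may have more. Where it says the series, first, only, none or still open, it means among the compounds named here.

Compound 1 `CCCCCC[C@@H](O)C/C=C\CCCCCCCC(=O)N[C@@H](C)c1ccccc1` gives 8.3 ug/mL
Compound 2 `CCCCCCCC/C=C\CCCCCCCC(=O)N1CCCC1` gives 45.6 ug/mL
Compound 3 `CCCCCCCCCCCCCCCC(=O)N1CCOCC1` gives 34.1 ug/mL

In a functional assay on NCI-H460 cells (Homo sapiens) for antiproliferative activity, read by sulforhodamine B assay, with a stated time of 48 h (on this read-out lower numbers stand for stronger inhibition of growth and higher numbers for weaker inhibition of growth), compound 1 has the lowest number of these three, and its gaps to compound 2 and compound 3 both lie beyond the usual scatter. Compound 4 `CCCCCC[C@@H](O)C/C=C\CCCCCCCC(=O)N1CCOCC1` has not yet been measured. It keeps the core of compound 1 and changes one group, with morpholin-4-yl in place of (1-phenylethyl)amino on a carbonyl carbon.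

Going by the values given here, no two measured compounds differ in just one place, so no measured step shows this swap directly. The nearest clue is compound 3, which carries morpholin-4-yl on a different chain and reads 34.1 ug/mL in this assay. That single comparison is weak evidence, but it suggests a loss of growth inhibition. The estimated step of a 2.4-fold higher number from compound 1 to compound 4 (0.38 log units; beyond the scatter) points toward a higher number in this assay and so toward weaker inhibition. For compound 4 the estimated value is 20 ug/mL with an expected range of 8 ug/mL to 50 ug/mL as the likely span.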

Compound 4, concentration for 50% growth inhibition: 49.1 ug/mL
Compound 4: middle estimate off by 2.5-fold (0.39 log units), on the low side; low and high end bracket the measured number.
By their numbers in this assay, from the lowest: compound 1; then compounds 3, 2 and 4 (each within the scatter of the next).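

Going by these compounds alone, this is the first direct reading of the swap with the rest of the molecule held fixed: in this assay the change gives a 5.9-fold higher number from compound 1 to compound 4 (0.77 log units; beyond the scatter) on the carbonyl carbon. Compound 4 keeps the core of compound 1, so that core alone does not secure the low number, and the group on the carbonyl carbon clearly counts. The swap removes the aromatic ring, the amide hydrogen and the defined stereocentre together, so this single step cannot show which of them matters.

The data offer no measured explanation for the rise in the number. Still open, going by these compounds, is whether a benzylamino group, which lacks the methyl branch, or a piperidin-1-yl group, which has carbon in place of the morpholine oxygen, would keep growth inhibition on this core.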